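The compounds below may be only part of what the source reports. "The series", "measured", "known", "first", "only" and "open" are said of these compounds alone.

Of the compounds shown here, two have been measured so far, both sharing the core of compound 1 `CCn1c(C(=O)NCCN)ccc1C(CC)(CC)c1ccc(OCS(=O)(=O)c2ccccc2)c(C)c1` and differing only in the group on the amide-type nitrogen. In a functional assay on PC-3 cells (Homo sapiens) for antiproliferative activity, read by MTT assay, with a stated time of 24 h (a higher number here means a weaker inhibitor, a lower number a stronger inhibitor), compound 1 gives 6890 nM. Compound 2 `CCn1c(C(=O)N[C@@H](CO)CCO)ccc1C(CC)(CC)c1ccc(OCS(=O)(=O)c2ccccc2)c(C)c1` carries a 3-hydroxy-1-(hydroxymethyl)propyl group there, and in this assay compound 2 gives 14100 nM, which is the highest of the two numbers; the step of a 2.0-fold higher number from compound 1 to compound 2 (0.31 log units; beyond the scatter) is modest but beyond the scatter.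

The next compound, compound 3 `CCn1c(C(=O)N[C@@H](CC(=O)O)C(=O)O)ccc1C(CC)(CC)c1ccc(OCS(=O)(=O)c2ccccc2)c(C)c1`, takes the change (1,2-dicarboxyethyl in place of 3-hydroxy-1-(hydroxymethyl)propyl on an amide-type nitrogen). Going by the values given here, the only measured step, a 2.0-fold higher number from compound 1 to compound 2 (0.31 log units; beyond the scatter), concerns a different exchange on the same nitrogen and does not bear directly on a 1,2-dicarboxyethyl group, so there is no close precedent. Given that the one exchange seen at this position moved the number only modestly, and that compound 2 already stands at the weak end, compound 3 is expected to fall near compound 2 or somewhat weaker, with the step of a 1.4-fold higher number from compound 2 to compound 3 (0.15 log units; within the scatter) as the estimate. Compound 3 is therefore estimated at 20000 nM in this assay, with a range from 7000 nM to 60000 nM.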

Compound 3, half-maximal inhibitory concentration: > 50000 nM
Compound 3 gave a limit, no number; the forecaster's own chance of this, stated with the estimate: 25%; middle value at least 2.5-fold (0.39 log units) away from the limit.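

Compound 3 reads in this assay as a limit and not as a number: the limit of > 50000 nM in this assay, at which 1 of the 3 values shown sits.

Going by these compounds alone, the group on the amide-type nitrogen turns out to matter more than the first pair of compounds could show, since 1,2-dicarboxyethyl in place of 3-hydroxy-1-(hydroxymethyl)propyl gives an at least 3.5-fold higher number from compound 2 to compound 3 (0.54 log units; beyond the scatter), and 1,2-dicarboxyethyl in place of 2-aminoethyl gives an at least 7.2-fold higher number from compound 1 to compound 3 (0.86 log units; beyond the scatter). Both steps are beyond the scatter, so compound 3 is the weakest of the three, and the order among these compounds runs from 2-aminoethyl through 3-hydroxy-1-(hydroxymethyl)propyl to 1,2-dicarboxyethyl.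

On these data alone, the full size of both steps stays open, as a limit gives no number for compound 3. Also open, as far as these compounds go, is whether a single carboxylic acid on a short chain, or a longer amine chain such as 3-aminopropyl, on the same nitrogen would give a number close to that of compound 1 or would move toward compound 3.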